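The compounds below may be only part of what the source reports. "The series", "measured", "known", "first", "only" and "open" are said of these compounds alone.

Compound 1 `Oc1ccccc1NC(=S)Nc1ccc2[nH]ccc2c1`: 4000 nM
Compound 2 `Oc1ccc(NC(=S)Nc2ccc3[nH]ccc3c2)cc1Cl`: 8600 nM
Compound 3 `Oc1cc(Cl)ccc1NC(=S)Nc1ccc2[nH]ccc2c1`: 300 nM

Three thioureas built on a shared indole-bearing core have been tested in an assay on cells for inhibition of Amine oxidase [flavin-containing] B (Homo sapiens), read by spectrophotometry; a lower number here means a stronger inhibitor, a higher number a weaker inhibitor. Compound 3 differs from compound 1 by chloro in place of hydrogen on an aromatic carbon, and that single change gave a 13-fold lower number from compound 1 to compound 3 (1.12 log units; beyond the scatter). Compound 2 gives the highest number of the three; how its core differs from that of compound 1 is not broken down here, and the two values simply show compound 2 to be the weaker of the pair.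

Compound 4 `Oc1c(Cl)cc(NC(=S)Nc2ccc3[nH]ccc3c2)cc1Cl` has not yet been measured. It differs from compound 2 by chloro in place of hydrogen on an aromatic carbon. Within the data shown here, this is the same kind of change as the one from compound 1 to compound 3, but not the same: in compound 4 the chloro enters ortho to a hydroxy group, meta to a chloro group and meta to a large group, whereas in compound 3 it entered meta to a hydroxy group and para to a large group. The author therefore expects a lower number for compound 4 in this assay, resting on the step of a 13-fold lower number from compound 1 to compound 3 (1.12 log units; beyond the scatter) that the same kind of change produced, while tempering the expectation since the surroundings of the new chloro are not those of compound 3. The expected step is a 3.4-fold lower number from compound 2 to compound 4 (0.54 log units; beyond the scatter). For compound 4 the estimate is 2500 nM, with a range from 600 nM to 8000 nM.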

Compound 4, half-maximal inhibitory concentration: 17000 nM
For compound 4 the middle estimate is 6.8-fold (0.83 log units) below the measured one; measured number outside the range, above it.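

In this assay, the replacement of hydrogen by chloro on an aromatic carbon gave a 2.0-fold higher number from compound 2 to compound 4 (0.30 log units; within the scatter), so the large step seen on the core of compound 1 did not recur on the core of compound 2, where the two numbers cannot be told apart. The change therefore did not carry from one core to the other with its effect intact, and the two steps differ by more than the scatter allows: the same change on two cores in this assay, a 13-fold lower number (1.12 log units; beyond the scatter) from compound 1 to compound 3 and a 2.0-fold higher number (0.30 log units; within the scatter) from compound 2 to compound 4, 26-fold (1.42 log units) apart, beyond the scatter of two such steps

Among these compounds, what this does not show is why the two steps differ, since only one pair stands on each core and the pairs differ in more than one respect: in compound 4 the chloro enters ortho to a hydroxy group, meta to a chloro group and meta to a large group, whereas in compound 3 it entered meta to a hydroxy group and para to a large group.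

The compounds shown leave open whether the outcome follows the place of the new chloro or the chloro group already present in compound 2. They also leave open whether a fluoro or a methoxy group at these places, or an amine in place of the hydroxy group, would follow either step.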